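A Methoxy Group Added Along the Ether Chain

The source may report more compounds than this note shows. Statements on the series, on what has been measured and on what is new or still open speak of the compounds shown alone.

Of the compounds shown here, three built on one shared core have been tested in an in vitro assay on 293-EBNA cells for binding affinity to corticotropin-releasing factor receptor 1 (Homo sapiens); a higher number here means a weaker inhibitor, a lower number a stronger inhibitor. Compound 1 `COCC(COC)N(C)c1nc(C)nc2c1nnn2-c1ccc(C(C)C)cc1Br` gives 21.3 nM in this assay. Compound 2 `CCCCNc1nc(C)nc2c1nnn2-c1ccc(C(C)C)cc1Br` gives 69.6 nM, and compound 3 `CCC(COC)Oc1nc(C)nc2c1nnn2-c1ccc(C(C)C)cc1Br` gives 1.9 nM. Compound 3 thus stands lowest of the three, and both of its steps are beyond the scatter: an 11-fold lower number from compound 1 to compound 3 (1.05 log units; beyond the scatter) and a 37-fold lower number from compound 2 to compound 3 (1.56 log units; beyond the scatter). The third step, a 3.3-fold higher number from compound 1 to compound 2 (0.51 log units; beyond the scatter), is modest.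

Compound 4 `COCC(COC)Oc1nc(C)nc2c1nnn2-c1ccc(C(C)C)cc1Br` has not yet been measured. It differs from compound 3 by methoxy in place of methyl on a saturated chain carbon, two bonds along the chain from an oxygen on an aromatic ring. Within the data shown here, none of the measured steps bears directly on this point: the two large steps to compound 3 exchange the whole group on the aromatic carbon, including the atom that joins it to the core, and the modest step from compound 1 to compound 2 does the same. Compound 1 does carry two methoxymethyl arms, as compound 4 would, but compound 1 also differs from compound 4 in the linking atom, so its value cannot isolate the effect of the added methoxy. Among the measured compounds shown here, with no measured pair testing this change alone, the expected step is a 1.8-fold higher number from compound 3 to compound 4 (0.27 log units; within the scatter), small and close to the scatter. Compound 4 is therefore estimated at 3.5 nM, within 1.2 nM to 12 nM.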

Compound 4, inhibition constant: 7.1 nM
Beside the measured number, compound 4's estimate is 2.0-fold (0.31 log units) below it; measured number inside the range.
By their numbers in this assay, from the lowest: compound 3; then compound 4; then compound 1; then compound 2.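

In this assay, among these compounds, methoxy in place of methyl on a saturated chain carbon, two bonds along the chain from an oxygen on an aromatic ring, gives a 3.7-fold higher number from compound 3 to compound 4 (0.57 log units; beyond the scatter), the only step here that changes this chain while the linking oxygen stays fixed, and it is modest but beyond the scatter. The added methoxy therefore gives up part of the advantage of compound 3 without removing the advantage over the groups joined through nitrogen: the steps are a 3.0-fold lower number from compound 1 to compound 4 (0.48 log units; beyond the scatter) and a 9.8-fold lower number from compound 2 to compound 4 (0.99 log units; beyond the scatter), and the first of these compares two groups that both carry two methoxymethyl arms. No accompanying measurement explains the step from methyl to methoxy.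

The compounds shown cannot separate the contribution of the added oxygen from that of the longer arm, a question that an ethyl or a hydroxy group at this place would address. They also leave open whether an ethoxy group or a longer chain would continue the same trend, and whether the same exchange would give a similar step on the nitrogen-linked group of compound 1.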